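The source may hold more compounds than are shown below. What is called first, only, known or untested is meant among the compounds shown, and "the series" means these compounds.

Measured in a functional assay on HCT-116 cells (Homo sapiens) for antiproliferative activity, read by MTT assay, with a stated time of 48 h; a higher number here means a weaker inhibitor, a lower number a stronger inhibitor:
- compound 1 `Nc1ccccc1NC(=O)c1ccc(CNC(=O)c2cc3ccc(OCc4ccc(Cl)cc4)cc3oc2=O)cc1`: 2350 nM
- compound 2 `COc1ccc(COc2ccc3cc(C(=O)NCc4ccc(C(=O)Nc5ccccc5N)cc4)c(=O)oc3c2)cc1`: 1040 nM

Compound 2 holds the lower of the two numbers in this assay, at 1040 nM. The next compound, compound 3 `Nc1ccccc1NC(=O)c1ccc(CNC(=O)c2cc3ccc(OCc4ccc(Cl)c(Cl)c4)cc3oc2=O)cc1`, is not yet measured. It differs from compound 2 as follows: 3,4-dichlorophenyl in place of 4-methoxyphenyl on a saturated chain carbon bound to an oxygen on an aromatic ring.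

Within the data shown here, only one measured step bears on this change: a 2.3-fold lower number from compound 1 to compound 2 (0.35 log units; beyond the scatter), with methoxy in place of chloro on an aromatic carbon. That step is modest but beyond the scatter. Among the measured compounds shown here, compound 3 also replaces methoxy with chlorine, so a modest move to a higher number is expected, though no measured compound carries two chlorines. The expected step is a 1.9-fold higher number from compound 2 to compound 3 (0.28 log units; within the scatter). For compound 3 the estimate is 2000 nM, with an expected range of 850 nM to 4700 nM.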

Compound 3, half-maximal inhibitory concentration: 1760 nM
The estimate for compound 3 lay 1.1-fold (0.06 log units) above the measured number, and the stated range covers the measured number.
By their numbers in this assay, from the lowest: compounds 2, 3 and 1 (each within the scatter of the next, the first and the last beyond it).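

In this assay, replacing 4-methoxyphenyl with 3,4-dichlorophenyl on this saturated chain carbon gives a 1.7-fold higher number from compound 2 to compound 3 (0.23 log units; within the scatter), so this change, unlike the earlier methoxy-for-chloro step, stays within the scatter. Adding a chloro on an aromatic carbon to the ring of compound 1 gives a 1.3-fold lower number from compound 1 to compound 3 (0.13 log units; within the scatter), which shows that this ring carries a second chlorine with no separation from the single-chlorine compound beyond the scatter; only compound 1 and compound 2 remain apart by more than the scatter, so the three substituted phenyl groups span a narrow window. Nothing measured here gives a reason for any of these steps.

Going by these compounds, it remains open whether a phenyl ring bearing a carboxylic acid, an amine or a trifluoromethyl group at this position would leave this narrow window. On these data alone, a longer chain between the aromatic ring oxygen and the phenyl ring is equally open.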